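The source may report more compounds than this note shows. Statements on the series, on what has been measured and on what is new or still open speak of the compounds shown alone.

Measured compounds:
- compound 1, `CCCCCCCCCCCCNC(=O)[C@@H](NC(=O)c1nccc2ccccc12)[C@@H](C)O`: 50500 nM
- compound 2, `CCCCCCCCCCCCCCNC(=O)[C@@H](NC(=O)c1cc2ccccc2o1)[C@@H](C)O`: 23400 nM

In a functional assay on MCF7 cells (Homo sapiens) for cytotoxicity, read by MTT assay, with a stated time of 48 h (on this read-out higher numbers stand for weaker inhibition and lower numbers for stronger inhibition), compound 2 gives 23400 nM, the lower of the two numbers shown. Compound 1 gives 50500 nM in this assay, a gap from compound 2 that lies beyond the scatter. The step under consideration leads from compound 2 to compound 3, `CCCCCCCCCCCCCCNC(=O)[C@@H](NC(=O)c1nccc2ccccc12)[C@@H](C)O`, which has not yet been measured. The change is isoquinolin-1-yl in place of 1-benzofuran-2-yl on a carbonyl carbon; the rest of the molecule stays as it is. For the measured compounds named here, no pair of measured compounds differs in only this one place, so the size of the step cannot be read from a measured pair. Compound 1 also carries an isoquinolin-1-yl group and gives 50500 nM in this assay, which points towards a weaker result for compound 3. Compound 3 is therefore expected to give 40000 nM in this assay, with a range from 15000 nM to 110000 nM. This estimate means a step of a 1.7-fold higher number from compound 2 to compound 3 (0.23 log units; within the scatter), expected to be modest and towards weaker inhibition.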

Compound 3, half-maximal inhibitory concentration: 22800 nM
Estimate against measurement, compound 3: 1.8-fold (0.24 log units) above, and the stated range covers the measured number.
By their numbers in this assay, from the lowest: compounds 3 and 2 (each within the scatter of the next); then compound 1.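

In this assay the exchange of 1-benzofuran-2-yl for isoquinolin-1-yl on the carbonyl carbon gives a 1.0-fold lower number from compound 2 to compound 3 (0.01 log units; within the scatter) and so leaves the read-out unmoved at this position. For the compounds shown here, with isoquinolin-1-yl held in place, ethyl in place of hydrogen on a saturated chain carbon gives a 2.2-fold lower number from compound 1 to compound 3 (0.35 log units; beyond the scatter) as a modest step beyond the scatter, so of these two single changes only the one in the chain shifts the number. No measurement shown here accounts for either step.

From the compounds shown here alone, whether a still longer chain would lower the number further remains open. So does whether a phenyl group on the carbonyl carbon, or an amine at the end of the chain, would keep it.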